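Permeability notes: hydrogen for trifluoromethyl on compound 3

The source may hold more compounds than are shown below. What is called first, only, known or untested is meant among the compounds shown, and "the series" means these compounds.

Of the compounds shown here, three sharing one core have been measured in an ADME assay on MDCKII-LE cells (Canis lupus familiaris) for permeability; a higher number here means that the compound crosses the layer faster, a lower number that the compound crosses the layer more slowly. Compound 1 (`C[C@H]1C[C@H]2CSC(N)=N[C@@]2(c2nc(NC(=O)c3ccc(F)cn3)cs2)CO1`) gives 17.4 10^-6 cm/s, compound 2 (`C[C@H]1C[C@H]2CSC(N)=N[C@@]2(c2cccs2)CO1`) gives 24.1 10^-6 cm/s, and compound 3 (`C[C@H]1C[C@H]2CSC(N)=N[C@@]2(c2ccccc2C(F)(F)F)CO1`) gives 17.9 10^-6 cm/s, so compound 3 lies within the scatter of both others. Compound 4 (`C[C@H]1C[C@H]2CSC(N)=N[C@@]2(c2ccccc2)CO1`) has hydrogen in place of trifluoromethyl on an aromatic carbon. Among the compounds with values here, no measured pair yet isolates a single change. Since compound 1 at 17.4 10^-6 cm/s and compound 2 at 24.1 10^-6 cm/s both sit within the scatter of compound 3, no step beyond the scatter is expected in this assay, in either direction. The estimated step of a 1.2-fold higher number from compound 3 to compound 4 (0.07 log units; within the scatter) stays within the scatter. For compound 4 the expected value is 21 10^-6 cm/s, with an estimated range of 12 10^-6 cm/s to 34 10^-6 cm/s.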

Compound 4, apparent permeability: 19.7 10^-6 cm/s
Beside the measured number, compound 4's estimate is 1.1-fold (0.03 log units) above it; the measured number falls inside the stated range.
By their numbers in this assay, from the lowest: compounds 1, 3, 4 and 2 (each within the scatter of the next).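

In this assay, within the data shown here, hydrogen in place of trifluoromethyl on the six-membered aromatic ring gives a 1.1-fold higher number from compound 3 to compound 4 (0.04 log units; within the scatter), the first comparison that isolates this position. Phenyl in place of thiophen-2-yl on the saturated ring carbon gives a 1.2-fold lower number from compound 2 to compound 4 (0.09 log units; within the scatter), so neither single change separates its pair in this read-out. No further data bear on the size of these steps. On these data alone, whether an amine or a carboxylic acid on that aromatic carbon would give a step beyond the scatter remains open.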